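A few compounds are considered here, and "the series" means these few. Any claim that something is new, unique, unknown or untested is made for them only; others in the source may bear on it.

Compounds measured so far in an assay for inhibition of inositol hexakisphosphate kinase 2 (Homo sapiens), read by colorimetric assay, coupled enzyme assay and malachite green, with a stated time of 120 min, in the presence of a further agent that is not named here; a higher number here means a weaker inhibitor, a lower number a stronger inhibitor:

Compound 1, `COC(=O)/C=C/c1ccc2noc(-c3ccccc3)c2c1`, gives 1580 nM.
Compound 2, `O=C(O)c1ccc2noc(-c3ccc(-c4cccnc4)cc3)c2c1`, gives 54 nM.
Compound 3, `O=C(O)c1ccc2noc(-c3ccc(-c4ccncc4)cc3)c2c1`, gives 150 nM.

Compound 3 stands second highest of the three numbers in this assay. Going by the values given here, its nearest neighbour is compound 2, and the only step that isolates a single change is a 2.8-fold higher number from compound 2 to compound 3 (0.44 log units; beyond the scatter). Compound 1, which carries an ester-bearing chain instead of the carboxylic acid and no further substituent on the phenyl ring, sits furthest from compound 3.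

The unmeasured compound 4 is `O=C(O)c1ccc2noc(-c3ccc(N4CCCCC4)cc3)c2c1`. Relative to compound 3 the change is piperidin-1-yl in place of pyridin-4-yl on an aromatic carbon. The step from compound 2 to compound 3 is the only measured one that touches this position, and it shows that swapping one six-membered ring bearing one hetero atom for another at this site moves the number modestly, beyond the scatter. Among the compounds with values here, no measured pair exchanges an aromatic ring for a non-aromatic one, so the direction of the new step rests on thin ground.

The account therefore expects a modest step in this assay, most likely towards a slightly higher number, as expressed by a 1.7-fold higher number from compound 3 to compound 4 (0.22 log units; within the scatter). Compound 4 is accordingly estimated at 250 nM, with a range from 80 nM to 800 nM.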

Compound 4, half-maximal inhibitory concentration: 240 nM
Compound 4: the middle estimate sits 1.0-fold (0.02 log units) above what was measured; the range from low to high includes it.
By their numbers in this assay, from the lowest: compound 2; then compounds 3 and 4 (each within the scatter of the next); then compound 1.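

In this assay, replacing the aromatic pyridin-4-yl with the non-aromatic piperidin-1-yl, on an aromatic carbon para to a large group, gives a 1.6-fold higher number from compound 3 to compound 4 (0.20 log units; within the scatter), so the two compounds cannot be told apart and, in this pair, an aromatic ring at this place is not required to hold the number. The same piperidin-1-yl set against pyridin-3-yl gives a 4.4-fold higher number from compound 2 to compound 4 (0.65 log units; beyond the scatter), a step beyond the scatter, so among these three compounds it is compound 2 alone that stands apart, and the choice between the two pyridine rings, seen in a 2.8-fold higher number from compound 2 to compound 3 (0.44 log units; beyond the scatter), matters more here than the loss of aromaticity from pyridin-4-yl to piperidin-1-yl. The material at hand offers no independent data that would explain either step.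

The compounds shown leave open whether other saturated rings at this place, such as morpholin-4-yl or piperazin-1-yl, or an open-chain amine such as dimethylamino, would behave like piperidin-1-yl or like pyridin-3-yl. They also leave open what pyridin-2-yl would give, and how much the carboxylic acid on the shared core contributes when it alone is exchanged, for example for a methyl ester.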